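A Methoxy Group Added to a Weaker Core

The source may report more compounds than this note shows. Statements on the series, on what has been measured and on what is new or still open speak of the compounds shown alone.

Three compounds from one series were measured in a functional assay on HeLa cells (Homo sapiens) for inhibition, read by cell counting, with a stated time of 4 days; on this read-out higher numbers stand for weaker inhibition and lower numbers for stronger inhibition. Compound 1 `C=C(Br)C(=O)Nc1cccc(-c2cn3nc(-c4ccccc4)sc3n2)c1` gives 1400 nM in this assay. Compound 2 `C=C(Br)C(=O)Nc1cccc(-c2cn3nc(-c4cccc(OC)c4)sc3n2)c1` carries one change against compound 1, (methoxy in place of hydrogen on an aromatic carbon), and in this assay compound 2 gives 1100 nM; the step of a 1.3-fold lower number from compound 1 to compound 2 (0.10 log units; within the scatter) is small. Compound 3 `Nc1cccc(-c2cn3c(-c4ccccc4)csc3n2)c1` belongs to a different core, and the difference between the two cores is not broken down here; in this assay compound 3 gives 60000 nM, far from the other two.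

Compound 4 `COc1ccc(-c2csc3nc(-c4cccc(N)c4)cn23)cc1` has not yet been measured. Against compound 3 it shows (methoxy in place of hydrogen on an aromatic carbon). This is the same kind of change as that from compound 1 to compound 2, but not the same: in compound 2 the new group sits meta to a large group, in compound 4 it sits para to a large group, and the two cores are not the same.

What is expected for compound 4 in this assay rests on two things: the value of compound 3, 60000 nM, which is its starting point, and the step of a 1.3-fold lower number from compound 1 to compound 2 (0.10 log units; within the scatter), which shows that adding a methoxy group on the other core did not move the number beyond the usual scatter. The step from compound 3 to compound 4 is therefore expected to be a 1.3-fold lower number from compound 3 to compound 4 (0.12 log units; within the scatter). Compound 4 is estimated to give 45000 nM in this assay, with a likely range from 18000 nM to 110000 nM.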

Compound 4, half-maximal inhibitory concentration: 19000 nM
Compound 4: the middle estimate sits 2.4-fold (0.37 log units) above what was measured, within the range that was stated.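

In this assay, methoxy in place of hydrogen on the core of compound 3 gives a 3.2-fold lower number from compound 3 to compound 4 (0.50 log units; beyond the scatter), a modest step. Set beside the earlier step on the other core, it does not differ from it by more than such a pair of steps can be expected to scatter: the same change on two cores in this assay, a 1.3-fold lower number (0.10 log units; within the scatter) from compound 1 to compound 2 and a 3.2-fold lower number (0.50 log units; beyond the scatter) from compound 3 to compound 4, 2.5-fold (0.39 log units) apart, within the scatter of two such steps. This shows that the change lowered the number on both cores and that the two sizes cannot be told apart, yet only the newer step lies beyond the scatter, and a single pair on each core does not establish that the step carries over at a fixed size, since the core and the place of the methoxy group both differ between the two pairs, with the group para to a large group in compound 4 but not in compound 2.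

The compounds shown leave open whether a hydroxyl or an ethoxy group in the same place on compound 3 would move the number as methoxy does, and whether methoxy at another place on that ring would give the same step. They also leave open whether the step would hold on the core of compound 3 with the bromine-bearing amide of compounds 1 and 2 in place of the amine.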